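The source may report more compounds than this note shows. Statements on the series, on what has been measured and on what is new or still open speak of the compounds shown alone.

Measured compounds:
Compound 1 `COc1ccc(C2=CC3CC(C2)CN(C)C3)cn1`: 797 nM
Compound 2 `Clc1cncc(C2=CC3CNCC(C2)C3)c1`: 0.4 nM
Compound 3 `COc1cncc(C2=CC3CNCC(C2)C3)c1`: 0.3 nM

In an in vitro assay on SH-EP1 cells for displacement of a labelled ligand from Neuronal acetylcholine receptor; alpha4/beta2 (Homo sapiens) (on this read-out lower numbers stand for stronger inhibition and higher numbers for weaker inhibition), compound 3 gives 0.3 nM and compound 2 gives 0.4 nM. The change between them is chloro in place of methoxy on an aromatic carbon, and the step of a 1.3-fold higher number from compound 3 to compound 2 (0.12 log units; within the scatter) lies within the scatter. Compound 1 stands far apart: in this assay compound 1 gives 797 nM. The difference between the core of compound 1 and the shared core of compounds 2 and 3 is not broken down here.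

Compound 4 `CN1CC2C=C(c3ccc(Cl)nc3)CC(C2)C1` is not yet measured. Its change from compound 1 is chloro in place of methoxy on an aromatic carbon. For the measured compounds named here, this is the same kind of change as the one from compound 3 to compound 2, but not the same: there the place is two atoms from the ring nitrogen and meta to a group of 9 heavy atoms, whereas here it is next to the ring nitrogen and para to a large group.

The expectation rests on the step of a 1.3-fold higher number from compound 3 to compound 2 (0.12 log units; within the scatter), which is within the scatter; the estimated step is a 1.3-fold higher number from compound 1 to compound 4 (0.10 log units; within the scatter). For compound 4 the estimate in this assay is 1000 nM, between 300 nM and 3500 nM.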

Compound 4, inhibition constant: 22 nM
For compound 4 the middle estimate is 45-fold (1.66 log units) above the measured one, and the stated range ends above it.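

Chloro in place of methoxy on an aromatic carbon gives much stronger inhibition on the core of compound 1 (a 36-fold lower number from compound 1 to compound 4 (1.56 log units; beyond the scatter)), so the near-silent result on the other core was no guide here. The two pairs differ in more than the core, since the place on the aromatic ring is not the same either, and the data do not show whether the core, the place or both set the size of the step. In this assay the change therefore does not carry over as a constant step between these two pairs: the same change on two cores in this assay, a 1.3-fold higher number (0.12 log units; within the scatter) from compound 3 to compound 2 and a 36-fold lower number (1.56 log units; beyond the scatter) from compound 1 to compound 4, 48-fold (1.68 log units) apart, beyond the scatter of two such steps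

Still open, as far as these compounds go, is whether chloro in place of methoxy next to the ring nitrogen would give a step of this size on the shared core of compound 2 and compound 3. Also open, from the compounds shown here alone, is how a methyl, a nitrile or an amine in place of the chloro of compound 4 would read.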